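A Hydroxymethyl Swap at the Limit of the Assay

A few compounds are considered here, and "the series" means these few. Any claim that something is new, unique, unknown or untested is made for them only; others in the source may bear on it.

Values from a functional assay on Jurkat cells (Homo sapiens) for cytotoxicity, with a stated time of 72 h (a higher number here means that more compound is needed for the effect, a lower number that less compound is needed), follow, each of them a limit:
Compound 1 (`C=C[C@@](C)(/C=C/c1ccc(OCc2ccccc2)cc1)CCC=C(C)C`): > 49000 nM (a limit)
Compound 2 (`C=C[C@](C)(CCCC(C)C)CCc1ccc(O)cc1`): > 49000 nM (a limit)
Compound 3 (`C=C[C@@](C)(/C=C/c1ccc(O)cc1)CCC1OC1(C)C`): > 49000 nM (a limit)

Compound 3 reports > 49000 nM as a limit and not a number. The whole set stands at one place (the limit of > 49000 nM in this assay, at which 3 of the 3 values shown sit). The step to compound 4 (`C=C[C@@](C)(/C=C/c1ccc(O)cc1)CCCO`) puts hydroxymethyl in place of 3,3-dimethyloxiran-2-yl on a saturated chain carbon, three bonds along the chain from two double-bonded chain carbons. Among the measured compounds shown here, no measured step gauges this change, so the expectation rests on compound 3 and its limit (> 49000 nM). In this assay no change beyond the scatter is expected (estimated step: a number no higher from compound 3 to compound 4 (the limit leaves the size open)). Compound 4 is estimated at 49000 nM within an expected range of 20000 nM to 100000 nM and a limit is the likeliest report.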

Compound 4, half-maximal effective concentration: > 49000 nM
Compound 4 was reported as a limit; the forecaster's own chance of this, stated with the estimate: 85%; the middle value lies on the limit itself.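

Among the compounds shown here, compound 3 and compound 4 both stand at a limit, so no step between them can be read. How far hydroxymethyl in place of 3,3-dimethyloxiran-2-yl moves the value in this assay stays open, because every compound shown stands at one place: the limit of > 49000 nM in this assay, at which 4 of the 4 values shown sit.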